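A few compounds are considered here, and "the series" means these few. Any claim that something is new, unique, unknown or untested is made for them only; others in the source may bear on it.

In an ADME assay on HepG2 cells (Homo sapiens) for cytotoxicity, read by CellTiter-Glo and ATP content, with a stated time of 72 h (on this read-out higher numbers stand for an effect only at larger amounts of compound and lower numbers for an effect already at smaller amounts), three compounds built on one shared core have been measured. Compound 1 `CS(=O)(=O)c1ccc(C(=O)N2CCC(C(=O)N(Cc3ccccc3)c3ccccc3)CC2)cc1[N+](=O)[O-]` carries a benzyl and a phenyl on its amide-type nitrogen. In this assay compound 1 gives only the limit of the measurement, > 27000 nM. Compound 2 `CN(Cc1ccccc1)C(=O)C1CCN(C(=O)c2ccc(S(C)(=O)=O)c([N+](=O)[O-])c2)CC1` differs by a methyl in place of that phenyl. In this assay compound 2 likewise reaches only a limit, > 27000 nM. Compound 3 `CN(CC(=O)N(Cc1ccccc1)Cc1ccccc1)C(=O)c1ccc(S(C)(=O)=O)c([N+](=O)[O-])c1` is a further member of the same series. In this assay compound 3 also stops at a limit, > 27000 nM. The step that the two limits leave unreadable from compound 1 to compound 2 therefore cannot be sized, because both ends sit at the limit of > 27000 nM in this assay, at which 3 of the 3 values shown sit. Compound 2 thus stands nowhere on a scale of numbers; it stands at the same limit as its two neighbours.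

Compound 4 `CC1Cc2ccccc2N1C(=O)C1CCN(C(=O)c2ccc(S(C)(=O)=O)c([N+](=O)[O-])c2)CC1` is built from compound 2 by the change (2-methyl-2,3-dihydro-1H-indol-1-yl in place of benzyl(methyl)amino on a carbonyl carbon). Within the data shown here, no measured step bears directly on this change, and the one measured step is unreadable. Compound 4 is expected to give about 30000 nM, between 10000 nM and 100000 nM, most likely again as a limit. The step from compound 2 to compound 4 is estimated at a step that the limit leaves unreadable from compound 2 to compound 4, meaning no shift beyond the scatter is expected.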

Compound 4, half-maximal effective concentration: > 27000 nM
Compound 4: a limit, no number; the forecaster's own chance of this, stated with the estimate: 85%; the middle value does not contradict the limit.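

In this assay compound 4 gives > 27000 nM as a limit, not a number. Compound 2 also gives only a limit, so no size can be read for the change from compound 2 to compound 4, and both stand with the others: the limit of > 27000 nM in this assay, at which 4 of the 4 values shown sit. The compounds shown leave open at what concentration, if any, each would affect these cells.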